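Changing the aryl group on the ring nitrogen of compound 2

A few compounds are considered here, and "the series" means these few. Any claim that something is new, unique, unknown or untested is made for them only; others in the source may bear on it.

Compound 2 `COc1c(F)cccc1N1C(=O)CSC1c1cccc(C(=O)NCCCCc2ccccc2)c1` has the lower of the two numbers measured: in a functional assay on MG-63 cells (Homo sapiens) for inhibition, read by CCK-8 assay, with a stated time of 72 h, tested at 1 uM (on this read-out lower numbers stand for less inhibition and higher numbers for more inhibition at the one concentration tested (going by the name of the read-out)), compound 2 gives 0%, while compound 1 `COc1ccc(F)cc1N1C(=O)CSC1c1cccc(C(=O)NCCCCc2ccccc2)c1` gives 86%. Compound 3 `COc1ccc(N2C(=O)CSC2c2cccc(C(=O)NCCCCc3ccccc3)c2)c(OC)c1` is not yet measured; it differs from compound 2 by 2,4-dimethoxyphenyl in place of 3-fluoro-2-methoxyphenyl on an amide-type nitrogen in a ring. Within the data shown here, the one measured step bears on this, since it also changed the group on the amide-type nitrogen in the ring: a number 86 percentage points lower from compound 1 to compound 2 (beyond the scatter). A change at this place can therefore move the read-out strongly, but its direction cannot be read from a single step. Compound 3 is expected to show a number 40 percentage points higher from compound 2 to compound 3 (beyond the scatter), an estimated 40%, with a wide range from 0% to 85%.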

Compound 3, a percentage reported as inhibition, at one concentration (the size of the read-out at that concentration, not a potency): 56%
The estimate for compound 3 lay 16 percentage points below the measured number; the range from low to high includes it.
By their numbers in this assay, from the lowest: compound 2; then compound 3; then compound 1.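

With a third aryl group on the ring nitrogen, this assay shows 2,4-dimethoxyphenyl sitting between the two fluorinated groups: there is a number 56 percentage points higher from compound 2 to compound 3 (beyond the scatter) and also a number 30 percentage points lower from compound 1 to compound 3 (beyond the scatter) for the same incoming group. The complete loss seen with 3-fluoro-2-methoxyphenyl is therefore not shared by every substituted phenyl at this position, though neither replacement of 5-fluoro-2-methoxyphenyl matches it. Nothing available explains these differences. The compounds shown leave open how a pyridine ring, or a phenyl ring carrying a dimethylamino group, would behave on this nitrogen.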